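Adding a Methoxy Group Where No Toxicity Has Appeared

A few compounds are considered here, and "the series" means these few. Any claim that something is new, unique, unknown or untested is made for them only; others in the source may bear on it.

Measured compounds:
compound 1 `Cc1nc(SCC(=O)Nc2nc(-c3ccc(Cl)cc3)cs2)n(Nc2ccccc2)c1C`: in a functional assay on MDA-MB-435 cells (Homo sapiens) for antiproliferative activity, read by sulforhodamine B assay, with a stated time of 48 h (on this read-out higher numbers stand for lower toxicity in this test and lower numbers for higher toxicity in this test), compound 1 gives > 100000 nM, a limit of the assay and not a number.
compound 2 `Cc1ccc(Nn2c(SCC(=O)Nc3nc(-c4ccccc4)cs3)nc(C)c2C)cc1`: in this assay compound 2 gives > 100000 nM, likewise a limit.

Where compound 1 stands: the limit of > 100000 nM in this assay, at which 2 of the 2 values shown sit. Among the compounds with values here, compound 1 therefore has no measured number, and the only other compound in this assay, compound 2, has none either, so the two cannot be set in any order and no measured step exists between them.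

Compound 3 `COc1ccc(Nn2c(SCC(=O)Nc3nc(-c4ccc(Cl)cc4)cs3)nc(C)c2C)cc1` has not yet been tested. It differs from compound 1 by one change: methoxy in place of hydrogen on an aromatic carbon. With both tested compounds sitting at the limit, this change is expected to give no step beyond the usual scatter in this assay, and compound 3 is expected to give about 100000 nM, within 30000 nM to 300000 nM, the expected step being a number no higher from compound 1 to compound 3 (the limit leaves the size open), with a further limit the most likely outcome.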

Compound 3, concentration lethal to 50% of the cells: > 100000 nM
Compound 3: only a limit was reported; the forecaster's own chance of this, stated with the estimate: 85%; the middle value lies on the limit itself.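

Compound 3, like compound 1, gives only a limit and not a number in this assay, so no step can be read between compound 1 and compound 3: the limit of > 100000 nM in this assay, at which 3 of the 3 values shown sit.

From the compounds shown here alone, whether methoxy in place of hydrogen on an aromatic carbon changes the toxicity at all remains open.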